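This account rests on a few compounds, and the source may have more. Where it says the series, first, only, none or still open, it means among the compounds named here.

Working notes on the series.

Two compounds share the core and differ only at the nitrogen on the aromatic ring. Compound 1 `CCOC(=O)N1CCC(NS(=O)(=O)c2ccc(NCCCc3ccccc3)c3ccccc23)CC1` carries a 3-phenylpropyl there, and in an assay on L1.2 cells for binding affinity to C-C chemokine receptor type 8 (Homo sapiens) (on this read-out lower numbers stand for stronger inhibition and higher numbers for weaker inhibition), compound 1 gives 32.1 nM. Compound 2 `CCOC(=O)N1CCC(NS(=O)(=O)c2ccc(NC(=O)N3CCCCC3)c3ccccc23)CC1` carries a (piperidin-1-yl)carbonyl instead, and in this assay compound 2 gives 126 nM. The one step shown, a 3.9-fold higher number from compound 1 to compound 2 (0.59 log units; beyond the scatter), is modest but beyond the scatter, and it leaves compound 2 with the highest of the two numbers recorded so far.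

Compound 3 `CCOC(=O)N1CCC(NS(=O)(=O)c2ccc(N)c3ccccc23)CC1` is not yet measured. Its difference from compound 2 is hydrogen in place of (piperidin-1-yl)carbonyl on a nitrogen on an aromatic ring; cut one bond further out, the change reads ((piperidin-1-yl)carbonyl)amino to amino. Among the measured compounds shown here, only the step from compound 1 to compound 2 bears on this position, and it shows that swapping what sits on this nitrogen moves the number by a modest amount. For the measured compounds named here, removing the group altogether has no direct precedent here, so the expectation rests on that single step. A further rise beyond the scatter is expected for compound 3, of about a 3.6-fold higher number from compound 2 to compound 3 (0.55 log units; beyond the scatter). The estimate for compound 3 in this assay is 450 nM, within a range from 120 nM to 2000 nM.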

Compound 3, inhibition constant: > 5000 nM
Compound 3: only a limit was reported (the forecaster's own chance of this, stated with the estimate: 10%); middle value at least 11-fold (1.04 log units) away from the limit.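

Compound 3 is reported only as a limit, not as a number: the limit of > 5000 nM in this assay, at which 1 of the 3 values shown sits.

Among the compounds shown here, the earlier compounds showed only that exchanging one group for another on this nitrogen moves the number modestly, a 3.9-fold higher number from compound 1 to compound 2 (0.59 log units; beyond the scatter). Removing the group altogether is a much larger change, both an at least 39-fold higher number from compound 2 to compound 3 (1.59 log units; beyond the scatter) and an at least 150-fold higher number from compound 1 to compound 3 (2.19 log units; beyond the scatter), and since these two steps rest on a limit, each gives a minimum size only. Across these three compounds, the two that carry a group on the nitrogen, 3-phenylpropyl in compound 1 and (piperidin-1-yl)carbonyl in compound 2, give measured numbers, whereas the free amino of compound 3 does not, so the position is sensitive to loss of the group and not only to its identity.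

On these data alone, how little has to sit on this nitrogen for a measurable number to return stays open, for instance a methyl or an acetyl. Also open, as far as these compounds go, is whether the terminal phenyl of the 3-phenylpropyl contributes to the lower number of compound 1, which a plain propyl chain or a benzyl would test.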